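This account rests on a few compounds, and the source may have more. Where it says the series, first, only, none or still open, it means among the compounds named here.

Measured compounds:
compound 1, `O=c1[nH]cnc2c1c(-c1ccsc1)cn2[C@@H]1O[C@H](CO)[C@@H](O)[C@H]1O`: 12000 nM
compound 2, `O=c1[nH]cnc2c1c(-c1cc3ccccc3o1)cn2[C@@H]1O[C@H](CO)[C@@H](O)[C@H]1O`: > 20000 nM
compound 3, `O=c1[nH]cnc2c1c(-c1ccccc1)cn2[C@@H]1O[C@H](CO)[C@@H](O)[C@H]1O`: > 20000 nM

Among the compounds with values here, in a functional assay on HL-60 cells (Homo sapiens) for antiproliferative activity, read by XTT assay, with a stated time of 72 h (on this read-out lower numbers stand for stronger inhibition and higher numbers for weaker inhibition), compound 1 gives 12000 nM, the only number among the three measured compounds. In this assay compound 2 reaches only a limit of the assay, > 20000 nM. In this assay compound 3 likewise stops at a limit, > 20000 nM. The two measured steps from compound 1 both replace the thiophen-3-yl group: an at least 1.6-fold higher number from compound 1 to compound 2 (0.22 log units; that floor lies within the scatter) and an at least 1.6-fold higher number from compound 1 to compound 3 (0.22 log units; that floor lies within the scatter). Their size is bounded by the limit of > 20000 nM in this assay, at which 2 of the 3 values shown sit, and the step that the two limits leave unreadable from compound 2 to compound 3 cannot be read at all.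

Compound 4, `Nc1nc2c(c(-c3ccsc3)cn2[C@@H]2O[C@H](CO)[C@@H](O)[C@H]2O)c(=O)[nH]1`, differs from compound 1 by amino in place of hydrogen on an aromatic carbon. Within the data shown here, none of the measured steps touches that position; all three concern the aryl group on the core of compound 1, so they carry no information about the amino group. The data therefore give no ground for expecting a step beyond the scatter in this assay, and compound 4 is expected at a 1.1-fold lower number from compound 1 to compound 4 (0.04 log units; within the scatter). Compound 4 is estimated at 11000 nM, with a range from 2500 nM to 40000 nM.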

Compound 4, half-maximal inhibitory concentration: > 20000 nM
Compound 4: only a limit was reported; the forecaster's own chance of this, stated with the estimate: 35%; at least 1.8-fold (0.25 log units) between middle value and limit.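

Within the data shown here, the earlier compounds changed only the aryl group, so compound 4 gives the first reading at the position between two ring nitrogen atoms. In this assay compound 4 reaches only a limit of the assay, > 20000 nM. Amino in place of hydrogen thus brings no lower number at this place, but it yields only an at least 1.6-fold higher number from compound 1 to compound 4 (0.22 log units; that floor lies within the scatter), and the true size of that step cannot be read because the value stops at the ceiling shared by most of the series: the limit of > 20000 nM in this assay, at which 3 of the 4 values shown sit.

The compounds shown do not tell whether a methyl group, a methoxy group or a chlorine atom at this place would give a number below that limit. They also leave open how the amino group behaves when phenyl or 1-benzofuran-2-yl stands in place of thiophen-3-yl.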